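Shortening a hexyl ether to an allenyl ether

The source may hold more compounds than are shown below. What is called first, only, known or untested is meant among the compounds shown, and "the series" means these compounds.

Compound 1 `C[C@H]1CO[C@]2(C)Oc3c(c4c(c5c3C[C@@H]3[C@@H](C)CO[C@]3(C)O5)C[C@@H]3[C@@H](C)CO[C@]3(C)O4)C[C@H]12` and compound 2 `CCCCCCOc1cc2c(c3c1C[C@@H]1[C@@H](C)CO[C@]1(C)O3)C[C@@H]1[C@@H](C)CO[C@]1(C)O2` have both been examined in a functional assay on aorta (Rattus norvegicus, strain Sprague-Dawley) for inhibition; a higher number here means that more compound is needed for the effect, a lower number that less compound is needed. In this assay compound 1 gives 12000 nM. For compound 2 the assay reports no number but only a limit, > 200000 nM, in this assay. Compound 2 thus stands at the edge of what the assay resolves, as the limit of > 200000 nM in this assay, at which 1 of the 2 values shown sits, records.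

Compound 3 `C=C=CCOc1cc2c(c3c1C[C@@H]1[C@@H](C)CO[C@]1(C)O3)C[C@@H]1[C@@H](C)CO[C@]1(C)O2` has not yet been tested. It differs from compound 2 by propa-1,2-dien-1-yl in place of pentyl on a saturated chain carbon bound to an oxygen on an aromatic ring; read one bond further out, the change is hexyloxy to (buta-2,3-dien-1-yl)oxy.

Within the data shown here, no step between measured compounds is available to calibrate this change. On these data alone, because compound 2 sits at > 200000 nM, the true value of compound 2 is unknown and the direction of any step from it cannot be fixed. The account expects compound 3 to stay weak in this assay, with an estimated value of 150000 nM and a range from 30000 nM to 400000 nM. The step this implies, an at least 1.3-fold lower number from compound 2 to compound 3 (0.12 log units; that floor lies within the scatter), is expected to be small or not beyond the scatter, and a further limit for compound 3 is considered likely.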

Compound 3, half-maximal effective concentration: 12000 nM
Estimate against measurement, compound 3: 13-fold (1.10 log units) above; the whole stated range lies above it.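

At the position on a saturated chain carbon bound to an oxygen on an aromatic ring, the group carried there clearly matters in this assay: replacing pentyl with propa-1,2-dien-1-yl gives an at least 16-fold lower number from compound 2 to compound 3 (1.22 log units; beyond the scatter). The change from hexyloxy to (buta-2,3-dien-1-yl)oxy therefore moves this ether out of the range where the assay returns no number and gives it a measured value, which compound 2 alone could not show. The step is only a floor and its full size remains unknown, because compound 2 is recorded solely as a limit: the limit of > 200000 nM in this assay, at which 1 of the 3 values shown sits.

The single step changes the length of the chain and introduces the two double bonds together, so the compounds shown do not separate these two differences, and it stays open whether a plain butyl chain at this place would behave like hexyl or like buta-2,3-dien-1-yl. On these data alone, it also stays open how a chain ending in an amine or a carboxylic acid would read in this assay.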